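This account rests on a few compounds, and the source may have more. Where it says the series, first, only, none or still open, it means among the compounds named here.

The measured compounds:
compound 1, `O=C(NO)c1ccc(NCc2nc(-c3ccc(C(F)(F)F)cc3)nn2-c2ccccc2)cc1`, 41.6%
compound 2, `O=C(NO)c1ccc(NCc2nc(-c3ccsc3)nn2-c2ccccc2)cc1`, 53.4%
compound 3, `O=C(NO)c1ccc(NCc2nc(-c3ccccc3)nn2-c2ccccc2)cc1`, 72.6%

In an assay on Sf9 cells for inhibition of protein deacetylase HDAC6 (Homo sapiens), read by fluorescence, with a stated time of 40 min, tested at 100 nM (on this read-out higher numbers stand for more inhibition at the one concentration tested (going by the name of the read-out) and lower numbers for less inhibition), compound 3 stands highest of the three; compound 2 lies nearest, as a number 19.2 percentage points higher from compound 2 to compound 3 (beyond the scatter) shows, and compound 1 lies furthest, as a number 31 percentage points higher from compound 1 to compound 3 (beyond the scatter) shows. Compound 4, `O=C(NO)c1ccc(NCc2nc(-c3cc4ccccc4s3)nn2-c2ccccc2)cc1`, has not yet been measured. It differs from compound 3 in one place: 1-benzothiophen-2-yl in place of phenyl on an aromatic carbon. The measured step that bears most on this change is the one in which thiophen-3-yl gives way to phenyl at the same position, a number 19.2 percentage points higher from compound 2 to compound 3 (beyond the scatter), a modest rise in favour of phenyl. The step of a number 11.8 percentage points higher from compound 1 to compound 2 (beyond the scatter) touches the same position but sets thiophen-3-yl against 4-(trifluoromethyl)phenyl and is less direct. Because a number 19.2 percentage points higher from compound 2 to compound 3 (beyond the scatter) shows a higher number for phenyl than for a five-membered aromatic ring holding a sulfur atom, and compound 4 again carries such a ring, a modest fall is expected, a number 17.6 percentage points lower from compound 3 to compound 4 (beyond the scatter). Compound 4 is therefore estimated at 55%, with a range from 35% to 75%.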

Compound 4, a percentage reported as inhibition, at one concentration (the size of the read-out at that concentration, not a potency): 65.5%
Compound 4: middle estimate off by 10.5 percentage points, on the low side; measured number inside the range.
By their numbers in this assay, from the lowest: compound 1; then compound 2; then compounds 4 and 3 (each within the scatter of the next).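

In this assay, the 1-benzothiophen-2-yl group and phenyl cannot be told apart at this position on the five-membered aromatic ring with 3 nitrogen (a number 7.1 percentage points lower from compound 3 to compound 4 (within the scatter)), which shows that a second aromatic ring here, fused to a sulfur-bearing ring, keeps the number within the scatter of compound 3. Carrying a five-membered aromatic ring with sulfur does not by itself set the level of compound 2 (a number 12.1 percentage points higher from compound 2 to compound 4 (beyond the scatter)), and 1-benzothiophen-2-yl also stands well clear of 4-(trifluoromethyl)phenyl (a number 23.9 percentage points higher from compound 1 to compound 4 (beyond the scatter)). Nothing available accounts for these differences.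

As far as these compounds go, how a saturated ring such as cyclohexyl, or a phenyl group bearing an amine or a carboxylic acid, would read at this position remains open. So does the 1-benzothiophen-3-yl group, and with it whether the point of attachment matters.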